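Swapping a Dimethoxyphenyl for a Hydroxyphenyl Group

The source may hold more compounds than are shown below. What is called first, only, known or untested is meant among the compounds shown, and "the series" means these compounds.

Measured compounds:
- compound 1 `COc1ccc(-c2ccc(-c3ccc(-c4nc5cc(C)ccc5[nH]4)cc3)cc2)cc1OC`: 1720 nM
- compound 2 `COc1cc(-c2ccc(-c3ccc(-c4nc5cc(C)ccc5[nH]4)cc3)cc2)cc(OC)c1OC`: 170 nM

In a functional assay on DWD cells (Homo sapiens) for inhibition, read by sulforhodamine B assay (on this read-out higher numbers stand for weaker inhibition of growth and lower numbers for stronger inhibition of growth), compound 1 gives 1720 nM, the higher of the two numbers, and compound 2 gives 170 nM. The next compound to be tested is compound 3 `Cc1ccc2[nH]c(-c3ccc(-c4ccc(-c5ccc(O)cc5)cc4)cc3)nc2c1`. It differs from compound 1 in one place: 4-hydroxyphenyl in place of 3,4-dimethoxyphenyl on an aromatic carbon. In words, 4-hydroxyphenyl stands in place of 3,4-dimethoxyphenyl on an aromatic carbon.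

Within the data shown here, only one measured step bears on this change: a 10-fold lower number from compound 1 to compound 2 (1.01 log units; beyond the scatter), a large step that came with methoxy in place of hydrogen. Among the measured compounds shown here, that step adds a methoxy, whereas this change removes both methoxy groups and brings in a hydroxy, which no measured compound carries. The guidance is therefore weak, and no clear shift is expected in this assay. The expected outcome is a 1.1-fold lower number from compound 1 to compound 3 (0.06 log units; within the scatter), which would lie within the scatter. Compound 3 is estimated at 1500 nM, with an expected range of 400 nM to 5000 nM.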

Compound 3, concentration for 50% growth inhibition: 21200 nM
Compound 3: the middle estimate sits 14-fold (1.15 log units) below what was measured; measured number above the stated range.
By their numbers in this assay, from the lowest: compound 2; then compound 1; then compound 3.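

In this assay, the change at this position is far from neutral: it gives a 12-fold higher number from compound 1 to compound 3 (1.09 log units; beyond the scatter), so growth inhibition is clearly weaker with 4-hydroxyphenyl than with 3,4-dimethoxyphenyl. Together with a 10-fold lower number from compound 1 to compound 2 (1.01 log units; beyond the scatter), this shows that the number moves strongly in both directions with what the terminal aromatic ring carries, falling with a third methoxy and rising with the swap to a single hydroxy. Nothing available gives a reason for this rise.

From the compounds shown here alone, two things changed in this one step, the methoxy groups left and a hydroxy entered, and their separate shares remain unknown. A plain phenyl, a 4-methoxyphenyl or a 4-aminophenyl group in this place would help to tell these shares apart and show whether the hydroxy itself matters.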